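A few compounds are considered here, and "the series" means these few. Any claim that something is new, unique, unknown or untested is made for them only; others in the source may bear on it.

Measured in a functional assay on HCT-116 cells (Homo sapiens) for inhibition, read by MTT assay, with a stated time of 72 h; a higher number here means a weaker inhibitor, a lower number a stronger inhibitor:
- compound 1 `CC1=NN(c2ccc(C)cc2)C(=O)[C@]12C(=O)C=CC[C@H]2c1ccc(C)cc1`: 3530 nM
- compound 2 `CC1=NN(c2ccc(C)cc2)C(=O)[C@@]12C(=O)C=CC[C@@H]2c1ccc(C)cc1`: 4150 nM

Among the compounds with values here, compound 2, at 4150 nM, stands level with the only other measured compound. Within the data shown here, the single measured step is a 1.2-fold higher number from compound 1 to compound 2 (0.07 log units; within the scatter), and it concerns (the fact that compounds 1 and 2 differ only in the configuration as drawn). All stereocentres are inverted in that pair, so the two are mirror images.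

Compound 3 `CC1=NN(c2ccc(C)cc2)C(=O)[C@]12C(=O)C=CC[C@@H]2c1ccc(C)cc1` is still unmeasured. Its relation to compound 2 is the two compounds have the same atoms and bonds and differ only in configuration as drawn: 1 of 2 stereo elements differ; a stereocentre at a saturated ring carbon is drawn R in compound 2 and S in compound 3. Nothing leaves and nothing enters, and a stereocentre at a saturated ring carbon is drawn R in compound 2 and S in compound 3.

Among the measured compounds shown here, compound 3 therefore matches neither measured compound in full configuration, and no measured step covers the inversion of a single stereocentre. The step of a 1.2-fold higher number from compound 1 to compound 2 (0.07 log units; within the scatter) is the nearest guide, but only a loose one. No step beyond the scatter is expected in this assay, and no direction is favoured, although the range is kept wide. The expected step is a 1.0-fold lower number from compound 2 to compound 3 (0.02 log units; within the scatter). Compound 3 is estimated at 4000 nM, with an expected range from 1500 nM to 10000 nM.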

Compound 3, half-maximal inhibitory concentration: 14600 nM
For compound 3 the middle estimate is 3.7-fold (0.56 log units) below the measured one, and the stated range ends below it.
By their numbers in this assay, from the lowest: compounds 1 and 2 (each within the scatter of the next); then compound 3.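

In this assay, the arrangement of the two stereocentres relative to each other now shows an effect on the number: inverting one stereocentre gives a 3.5-fold higher number from compound 2 to compound 3 (0.55 log units; beyond the scatter), and inverting the other gives a 4.1-fold higher number from compound 1 to compound 3 (0.62 log units; beyond the scatter). Both steps are modest, and both lead to the same compound, which makes compound 3 the weakest of the three in this assay. The mirror-image pair alone gave no sign of this, as its step is a 1.2-fold higher number from compound 1 to compound 2 (0.07 log units; within the scatter) and inverting both stereocentres together leaves the number within the scatter; the gap seen here goes with configuration alone: the fact that compounds 2 and 3 differ only in the configuration as drawn

Open, as far as these compounds go, is where the mirror image of compound 3 would fall, and so whether the weaker number belongs to this relative configuration as such or to compound 3 alone. Also open, from the compounds shown here alone, is whether the gap between these stereoisomers would hold if an amine or a carboxylic acid were carried on the shared core.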